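This account rests on a few compounds, and the source may have more. Where it says the series, first, only, none or still open, it means among the compounds named here.

In an ADME assay on a cell-free system (plasma, Mus musculus) for protein binding, using ultracentrifugation (a higher number here means a larger unbound share of the compound, a lower number a smaller unbound share), compound 1 `CCNC(=O)Nc1nc2cc(-c3cnc(C(C)(C)O)nc3)cc(-c3cc(CN4CCC(C)(O)C4)ccn3)c2s1` reads 0.194 and compound 2 `CCNC(=O)Nc1nc2cc(-c3cnc(C(C)(C)O)nc3)cc(-c3cc(CN4CCCC4)ccn3)c2s1` reads 0.067 while compound 3 `CCNC(=O)Nc1nc2cc(-c3cnc(C(C)(C)O)nc3)cc(-c3cc(CN4CC(C)(O)C4)ccn3)c2s1` reads 0.223 on the same scale. Compound 3 therefore stands level with compound 1 and apart from compound 2. The next structure is compound 4 `CCNC(=O)Nc1nc2cc(-c3cnc(C(C)(C)O)nc3)cc(-c3cc(CN4CC[C@@H](O)C4)ccn3)c2s1` and the change is 3-hydroxypyrrolidin-1-yl in place of 3-hydroxy-3-methylazetidin-1-yl on a saturated chain carbon bound to an aromatic carbon with a hydroxy group still on the ring.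

Two kinds of measured step bear on this. Exchanging the same two ring sizes with hydroxy and methyl both retained gave a 1.1-fold higher number from compound 1 to compound 3 (0.06 log units; within the scatter) and so showed no real shift. Losing both hydroxy and methyl gave a 2.9-fold lower number from compound 1 to compound 2 (0.46 log units; beyond the scatter) and the matching comparison gave a 3.3-fold higher number from compound 2 to compound 3 (0.52 log units; beyond the scatter) as a modest step, but compound 4 keeps its hydroxy group. Removal of the methyl alone has no measured step in this set. No step beyond the scatter is therefore expected in this assay for this change. The estimated step is a 1.1-fold lower number from compound 3 to compound 4 (0.03 log units; within the scatter) in size. For compound 4 the expected unbound fraction is 0.21 with an estimated range of 0.13 to 0.33 on measurement.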

Compound 4, unbound fraction: 0.194
Compound 4: the middle estimate sits 1.1-fold (0.03 log units) above what was measured, within the range that was stated.
By their numbers in this assay, from the lowest: compound 2; then compounds 1, 4 and 3 (each within the scatter of the next).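

Hydroxy in place of hydrogen on a saturated ring carbon is now seen as a single change in this assay and gives a 2.9-fold higher number from compound 2 to compound 4 (0.46 log units; beyond the scatter) without any accompanying methyl group. Taking away the methyl group gives no change at the digits printed from compound 1 to compound 4 (within the scatter) and the exchange of 3-hydroxy-3-methylazetidin-1-yl for 3-hydroxypyrrolidin-1-yl gives a 1.1-fold lower number from compound 3 to compound 4 (0.06 log units; within the scatter) so compounds 1, 3 and 4, all carrying hydroxy, stand level while compound 2, without it, stands apart. Nothing available explains these steps.

Still open, on these data alone, is whether a methoxy group, an amine or a carboxylic acid on that ring carbon would read like hydroxy. Also open, as far as these compounds go, is whether the opposite arrangement at the defined stereocentre of compound 4 would read the same.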